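The compounds below may be only part of what the source reports. "The series", "measured", "known", "first", "only" and "open" are said of these compounds alone.

Measured so far in an ADME assay on HepG2 2.2.15 cells (Homo sapiens) for cytotoxicity, with a stated time of 9 days; on this read-out lower numbers stand for higher toxicity in this test and higher numbers for lower toxicity in this test:
compound 1 `COc1cccc(SCc2nc3c(Cn4ccnc4C)c(O)ccc3n2C)c1`, 103000 nM
compound 2 `Cn1c(CSc2ccc(F)cc2)nc2c(CN3CCCC3)c(O)ccc21`, 74800 nM
compound 3 `Cn1c(C[S+]([O-])c2ccccc2)nc2c(Cn3ccnc3)c(O)ccc21`, 557000 nM

Among these three compounds, which share one core, compound 3 stands highest in this assay. Its number lies beyond the usual scatter above that of compound 1, the nearest of the other two, and further still above that of compound 2, so compound 3 is the least toxic of the three in this read-out. Within the data shown here, no two of the measured compounds differ in just one place, so no single step between them can be read off.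

Compound 4 `Cc1ccc([S+]([O-])Cc2nc3c(Cn4ccnc4)c(O)ccc3n2C)cc1` has not yet been measured. It differs from compound 3 in one place: methyl in place of hydrogen on an aromatic carbon. A change of this size, a single carbon added to a ring that is already present, gives no reason in these data to expect a move beyond the scatter. The step from compound 3 to compound 4 in this assay is therefore expected to be small, a 1.2-fold lower number from compound 3 to compound 4 (0.09 log units; within the scatter), with a slight lean toward a lower number. On that basis compound 4 is estimated to give about 450000 nM in this assay, within a range from 200000 nM to 1000000 nM.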

Compound 4, half-maximal cytotoxic concentration: 758000 nM
Estimate against measurement, compound 4: 1.7-fold (0.23 log units) below; the measured number falls inside the stated range.
By their numbers in this assay, from the lowest: compounds 2 and 1 (each within the scatter of the next); then compounds 3 and 4 (each within the scatter of the next).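

In this assay, among these compounds, this is the first pair in the set that differs in one place, and it gives a 1.4-fold higher number from compound 3 to compound 4 (0.13 log units; within the scatter). Methyl in place of hydrogen on the six-membered aromatic ring, para to a large group, therefore leaves the read-out unchanged as far as this test can resolve, and the phenyl to 4-methylphenyl change can be read as a neutral step in this one pair. No accompanying measurement bears on why the step is this small, so the result stands as an observation of size alone.

A single methyl step leaves open how this same place on the ring would respond to a different kind of group, such as an amine, a carboxylic acid or a longer chain. It also leaves open whether methyl would give a step of similar size in the setting of compound 1 or compound 2, which differ from compound 3 in more than one place.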